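The compounds below may be only part of what the source reports. "The series", "measured", "known", "first", "only" and "open" are said of these compounds alone.

Measured in a functional assay on NALM-6 cells (Homo sapiens) for cytotoxicity, with a stated time of 72 h; a lower number here means that less compound is needed, a higher number that more compound is needed for the effect:
- compound 1, `C=C[C@@](C)(/C=C/c1ccc(OCc2ccccc2)cc1)CCC=C(C)C`: > 43400 nM
- compound 2, `C=C[C@@](C)(/C=C/c1ccc(O)cc1)CC/C=C(\C)C=O`: 12600 nM
- compound 3, `C=C[C@@](C)(/C=C/c1ccc(O)cc1)CC/C=C(C)/C=C/C(=O)OCc1ccccc1`: 36000 nM.

Compound 1 gives a limit of this assay, not a number; it sits at the limit of > 43400 nM in this assay, at which 1 of the 3 values shown sits. Among the compounds with values here, compound 2 and compound 3 give numbers, but neither differs from compound 1 in one place, so no step can be drawn from them to compound 1.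

Compound 4, `C=C[C@@](C)(/C=C/c1ccc(-c2cccc(Br)c2)cc1)CCC=C(C)C`, is not yet measured. It differs from compound 1 by 3-bromophenyl in place of benzyloxy on an aromatic carbon. Within the data shown here, no measured step anchors this change. The expectation is a step no larger than the scatter, from a starting point that is itself only a limit. Compound 4 is expected at 35000 nM, in a range 10000 nM to 90000 nM; the implied step an at least 1.2-fold lower number from compound 1 to compound 4 (0.09 log units; that floor lies within the scatter) is an estimate only, and another limit is about as likely as a number.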

Compound 4, half-maximal effective concentration: > 43400 nM
Compound 4 ended at the assay's limit; the forecaster's own chance of this, stated with the estimate: 50%; middle value at least 1.2-fold (0.09 log units) away from the limit.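

In this assay, compound 1 and compound 4 both give limits rather than numbers, so no step can be read between them: the limit of > 43400 nM in this assay, at which 2 of the 4 values shown sit.

Going by these compounds, whether 3-bromophenyl in place of benzyloxy shifts the value at all remains open.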